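Aryl sulfonamide series: dichlorophenyl in place of dimethylphenyl

The source may report more compounds than this note shows. Statements on the series, on what has been measured and on what is new or still open speak of the compounds shown alone.

Three compounds have numbers in a functional assay on DLD-1 cells (Homo sapiens) for antiproliferative activity, read by CellTiter-Glo, with a stated time of 72 h; a lower number here means a stronger inhibitor, a higher number a weaker inhibitor. Compound 2 `Cc1ccc(S(=O)(=O)N2CCC(N3CCC(C)CC3)CC2)cc1C` gives 24 nM, the lowest of the three. Compound 3 `CC1CCN(C2CCN(S(=O)(=O)c3cc(F)c(Br)c(F)c3)CC2)CC1` gives 107 nM, beyond the scatter from compound 2, and compound 1 `Cc1cc(C)c(S(=O)(=O)N2CCN(C3CCN(C)CC3)CC2)c(C)c1`, built on a different core, gives 426 nM, the furthest away. Compound 4 `CC1CCN(C2CCN(S(=O)(=O)c3cc(Cl)cc(Cl)c3)CC2)CC1` is not yet measured and differs from compound 2 in one place: 3,5-dichlorophenyl in place of 3,4-dimethylphenyl on a sulfonyl sulfur. Among the measured compounds shown here, no single-change step between measured compounds exists, so the size of this move is uncertain; that compound 3, with 107 nM, sits above compound 2 suggests a modest loss rather than a gain. The expected step is a 2.5-fold higher number from compound 2 to compound 4 (0.40 log units; beyond the scatter), toward weaker inhibition. Compound 4 is estimated at 60 nM, within 20 nM to 180 nM.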

Compound 4, half-maximal inhibitory concentration: 3400 nM
Compound 4: the middle estimate sits 57-fold (1.75 log units) below what was measured; measured number above the stated range.
By their numbers in this assay, from the lowest: compound 2; then compound 3; then compound 1; then compound 4.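

In this assay, the group on the sulfonyl sulfur proves far from interchangeable: a 140-fold higher number from compound 2 to compound 4 (2.15 log units; beyond the scatter). Among the compounds shown here, this is the first single-change reading at this position, and the loss is large even though the two groups match in heavy-atom count, hydrogen-bond donors and acceptors, and net charge. Nothing measured here bears on the origin of this loss.

The compounds shown leave open whether the chlorine atoms or their placement on the ring carry the loss. A 3,4-dichlorophenyl or a 3,5-dimethylphenyl group on the same sulfonyl sulfur would separate the two.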